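Series notes: anilino versus benzylamino arms on the shared core

The compounds below may be only part of what the source reports. "The series", "measured", "known", "first", "only" and "open" are said of these compounds alone.

Three compounds have numbers in a functional assay on MCF7 cells (Homo sapiens) for inhibition, read by CCK-8 assay, with a stated time of 48 h; a lower number here means a stronger inhibitor of growth, a higher number a weaker inhibitor of growth. Compound 1 `Cc1ccccc1Nc1nc(Nc2ccc(N3CCNCC3)cn2)ncc1Cl` gives 3410 nM, and compound 2 `Cc1ccccc1Nc1nc(Nc2ccc(N3CCCN(C)CC3)cc2)ncc1Cl` gives 4290 nM. Going by the values given here, compound 3 `COc1ccc(CNc2nc(Nc3ccc(N4CCN(C)CC4)cn3)ncc2Cl)cc1`, the only member carrying a benzyl arm rather than an anilino arm on the shared core, gives 17300 nM, the highest of the three numbers, above compound 2 and further above compound 1. Compound 4 `CN1CCN(c2ccc(Nc3ncc(Cl)c(Nc4ccc(C(C)(C)C)cc4)n3)nc2)CC1` has not been measured. It differs from compound 3 in one place: 4-(tert-butyl)phenyl in place of 4-methoxybenzyl on a nitrogen on an aromatic ring. Among the compounds with values here, no step between measured compounds is available for this change, so its size must be estimated. Because compound 1 gives 3410 nM and compound 2 gives 4290 nM, both with an aromatic ring set directly on the nitrogen, compound 4 is expected to move toward them, with a step of a 3.5-fold lower number from compound 3 to compound 4 (0.54 log units; beyond the scatter) beyond the scatter, toward a lower number. Compound 4 is estimated at 5000 nM, with a range from 1500 nM to 17000 nM.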

Compound 4, concentration for 50% growth inhibition: 12600 nM
Beside the measured number, compound 4's estimate is 2.5-fold (0.40 log units) below it; the range from low to high includes it.
By their numbers in this assay, from the lowest: compounds 1 and 2 (each within the scatter of the next); then compounds 4 and 3 (each within the scatter of the next).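

In this assay, going by these compounds alone, the first one-place comparison at this nitrogen gives a 1.4-fold lower number from compound 3 to compound 4 (0.14 log units; within the scatter), with 4-(tert-butyl)phenyl in place of 4-methoxybenzyl. Setting the aromatic ring directly on the nitrogen therefore leaves compound 4 and compound 3 within the scatter when the tert-butyl group enters at the same time. No measurement bearing on this result is available to explain it. The step changes the ring's attachment and its substituent together, and the two cannot be read separately. As far as these compounds go, whether a 4-methoxyphenyl or 4-(tert-butyl)benzyl arm would separate them remains open.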